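Swapping 4-methoxyphenoxy for benzyl on compound 2

The source may hold more compounds than are shown below. What is called first, only, known or untested is meant among the compounds shown, and "the series" means these compounds.

- Compound 1 `COc1cccc(CNCCCNc2ccnc3cc(-c4ccc(F)cc4)ccc23)c1O`: 6840 nM
- Compound 2 `COc1ccc(Oc2ccc3c(NCCCNCc4cc(F)ccc4OC)ccnc3c2)cc1`: 7000 nM
- Compound 3 `COc1cccc(CNCCCNc2ccnc3cc(Cc4ccc(F)cc4)ccc23)c1O`: 4780 nM

All three numbers come from an ADME assay on HepG2 cells (Homo sapiens) for cytotoxicity, read by luminescence, CellTiter-Glo and ATP content, with a stated time of 72 h; a higher number here means that more compound is needed for the effect, a lower number that less compound is needed. Repeated measurements of this kind naturally vary, and these three values lie within that scatter of one another. Compound 2 therefore cannot be separated from compound 1 or compound 3 on these numbers.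

Compound 4 `COc1ccc(F)cc1CNCCCNc1ccnc2cc(Cc3ccccc3)ccc12` has not yet been measured. It carries benzyl in place of the 4-methoxyphenoxy of compound 2 on an aromatic carbon: benzyl in place of 4-methoxyphenoxy on an aromatic carbon.

For the measured compounds named here, no measured pair shows this exact swap. The closest evidence is a 1.4-fold lower number from compound 1 to compound 3 (0.16 log units; within the scatter), where 4-fluorobenzyl replaces 4-fluorophenyl on an aromatic carbon. That step is small and stays within the scatter. It is only a loose guide, since the group leaving there is a different one. Compound 3, which carries 4-fluorobenzyl, gives 4780 nM, close to the other two values. In this assay, no step beyond the scatter is therefore expected.

The expected change is a 1.3-fold lower number from compound 2 to compound 4 (0.10 log units; within the scatter).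

For compound 4 the estimated value is 5500 nM, with an expected range from 2800 nM to 11000 nM.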

Compound 4, half-maximal effective concentration: 7990 nM
Compound 4: middle estimate off by 1.5-fold (0.16 log units), on the low side, within the range that was stated.
By their numbers in this assay, from the lowest: compounds 3, 1, 2 and 4 (each within the scatter of the next).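

For the compounds shown here, on the aromatic carbon that carries this group, benzyl in place of 4-methoxyphenoxy gives a 1.1-fold higher number from compound 2 to compound 4 (0.06 log units; within the scatter) in this assay, the first direct reading of this exact swap. The change removes a whole set of features at once: the oxygen atoms and hydrogen-bond acceptors of 4-methoxyphenoxy leave, and a smaller, all-carbon group enters, yet the number stays within the scatter. This pair therefore shows that, on the side chain of compound 2, the read-out does not separate these two groups, but no measurement on hand explains why.

From the compounds shown here alone, both groups in this pair end in an aromatic ring of carbon only, so it remains open whether a different kind of group at this place, such as an amine or a carboxylic acid, would move the number beyond the scatter. Going by these compounds, it also remains open whether the same swap would read the same way with the differently substituted benzyl on the chain of compound 1 and compound 3.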